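A few compounds are considered here, and "the series" means these few. Any claim that something is new, unique, unknown or untested is made for them only; others in the source may bear on it.

Measured so far:
- compound 2 `COc1cc(COc2ccc(C(=O)NN)cc2)cc(OC)c1OC` gives 264 ug/mL in a physicochemical assay, with a stated time of 30 min; on this read-out higher numbers stand for weaker inhibition and lower numbers for stronger inhibition
- compound 1 `CCOC(=O)c1ccc(OCc2cc(OC)c(OC)c(OC)c2)cc1` gives only a limit in this assay, namely > 100 ug/mL

Compound 2 stands as the sole numbered result in this assay; the other value shown is a limit, not a number. Among the measured compounds shown here, the one measured step, a step that the limit leaves unreadable from compound 1 to compound 2, cannot be read for size, since the limit of > 100 ug/mL in this assay, at which 1 of the 2 values shown sits, leaves its starting point open. Compound 3 `COc1cc(COc2ccc(C(=O)N/N=C/c3cc(Br)cc(Cl)c3O)cc2)cc(OC)c1OC` has not yet been measured. It differs from compound 2 by a group of 11 heavy atoms (7 carbon, 1 nitrogen, 1 oxygen, 1 chlorine, 1 bromine; one six-membered aromatic ring of carbon only) in place of one nitrogen atom, on an amide-type nitrogen. For the measured compounds named here, no measured step covers a change of this kind, so the expectation rests on the change itself: a large group enters in place of a single nitrogen atom on the amide-type nitrogen. A step toward stronger inhibition, beyond the usual scatter, is expected in this assay, though with wide uncertainty on either side. For compound 3 the estimated value is 50 ug/mL, with a likely range from 15 ug/mL to 150 ug/mL. The expected step of a 5.3-fold lower number from compound 2 to compound 3 (0.72 log units; beyond the scatter) would then be a moderate one.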

Compound 3, half-maximal inhibitory concentration: > 100 ug/mL
Compound 3: no number, only a limit; the forecaster's own chance of this, stated with the estimate: 10%; middle value at least 2.0-fold (0.30 log units) away from the limit.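

In this assay compound 3 gives > 100 ug/mL as a limit, not a number. No size can be read for the change from compound 2 to compound 3, because the comparison rests on that limit: the limit of > 100 ug/mL in this assay, at which 2 of the 3 values shown sit. The compounds shown leave open how the inhibition by compound 1 and compound 3 compares with that by compound 2.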